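A few compounds are considered here, and "the series" means these few. Any claim that something is new, unique, unknown or untested is made for them only; others in the source may bear on it.

Compound 2 `COc1cc(-c2nc3ccccc3c(=O)[nH]2)ccc1OS(C)(=O)=O` holds the higher of the two readings so far in an ADME assay on cell membranes (microsomes) for inhibition of cytochrome P450 1A1 (Homo sapiens), read by fluorescence, tested at 10 uM; on this read-out higher numbers stand for more inhibition at the one concentration tested (going by the name of the read-out) and lower numbers for less inhibition; in this assay compound 2 gives 32.6%, while compound 1 `COc1cc(-c2nc3ccccc3c(=O)[nH]2)ccc1OCc1ccc(Cl)cc1Cl` gives 21.1%. Among the compounds with values here, the one measured step bearing on the new compound is a number 11.5 percentage points higher from compound 1 to compound 2 (beyond the scatter), the only step at this oxygen. Compound 3 `COc1cc(-c2nc3ccccc3c(=O)[nH]2)ccc1OCc1ccc(F)cc1` carries the change (4-fluorobenzyl in place of methylsulfonyl on an oxygen on an aromatic ring), which brings back a benzyl ether in place of the methylsulfonyl, so a reading closer to compound 1 is expected, and the step of a number 10.6 percentage points lower from compound 2 to compound 3 (beyond the scatter) is estimated to run downward. Compound 3 is therefore expected to give 22%, within 8% to 38%.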

Compound 3, a percentage reported as inhibition, at one concentration (the size of the read-out at that concentration, not a potency): 6.3%
Estimate against measurement, compound 3: 15.7 percentage points above; the measured number lies below the stated range.
By their numbers in this assay, from the lowest: compound 3; then compound 1; then compound 2.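

In this assay, the benzyl ethers do not share one level: the step of a number 14.8 percentage points lower from compound 1 to compound 3 (beyond the scatter), with 4-fluorophenyl in place of 2,4-dichlorophenyl, shows that the ring of the benzyl group alone moves the reading. The step of a number 26.3 percentage points lower from compound 2 to compound 3 (beyond the scatter) places methylsulfonyl and 4-fluorobenzyl at the two ends of the three readings at this oxygen, with the 2,4-dichlorobenzyl ether in the middle. Nothing available explains these differences. As far as these compounds go, what an unsubstituted benzyl group or a plain methyl group would give on this oxygen remains open, as does whether a single chlorine on the benzyl ring would read nearer compound 1 or compound 3.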